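Dichloroacetamide biaryl series: a pyridin-2-yl variant

This account rests on a few compounds, and the source may have more. Where it says the series, first, only, none or still open, it means among the compounds named here.

Measured compounds:
compound 1, `O=C(Nc1cccc(-c2ccoc2)c1)C(Cl)Cl`, 8480 nM
compound 2, `COc1ccccc1-c1cc(NC(=O)C(Cl)Cl)cc(-c2ccccc2OC)c1`, 25500 nM
compound 3, `O=C(Nc1cccc(-c2ccc(Cl)cc2)c1)C(Cl)Cl`, 36200 nM

All three were run in a functional assay on A549 cells (Homo sapiens) for cytotoxicity, read by MTT assay, with a stated time of 68 h; a lower number here means a stronger inhibitor, a higher number a weaker inhibitor. Compound 1 gives the lowest number of the three and is the strongest inhibitor in this set; compound 2 lies beyond the scatter above it, and compound 3 further again. Among the measured compounds shown here, none of the measured pairs differs in a single place, so no step between measured compounds can be set out here; the numbers only show that the furan-3-yl compound 1 sits below both of the phenyl-bearing compounds.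

Compound 4, `O=C(Nc1cccc(-c2ccccn2)c1)C(Cl)Cl`, has not been measured. Its structural change from compound 1 is pyridin-2-yl in place of furan-3-yl on an aromatic carbon. Both the leaving and the entering group carry one hetero atom and one hydrogen-bond acceptor, and the shared core is unchanged.

For the measured compounds named here, with no single-place step among the measured compounds to lean on, the expectation for the step of a 1.4-fold higher number from compound 1 to compound 4 (0.15 log units; within the scatter) is a small move toward a higher number, possibly within the scatter. Compound 4 is therefore expected to give about 12000 nM in this assay, with a range from 4000 nM to 40000 nM, the wide span reflecting the thin basis for the estimate.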

Compound 4, half-maximal inhibitory concentration: > 50000 nM
Compound 4 ended at the assay's limit (the forecaster's own chance of this, stated with the estimate: 15%); at least 4.1-fold (0.61 log units) between middle value and limit.
By their numbers in this assay, from the lowest: compound 1; then compounds 2 and 3 (each within the scatter of the next). At a limit, above all of these: compound 4.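

Compound 4 gives > 50000 nM in this assay, and this value is a limit of the assay, not a number: the limit of > 50000 nM in this assay, at which 1 of the 4 values shown sits. Pyridin-2-yl in place of furan-3-yl on an aromatic carbon gives an at least 5.8-fold higher number from compound 1 to compound 4 (0.77 log units; beyond the scatter), the first step in this set that can be read at a single place, on a ring of carbon only and meta to a group of 6 heavy atoms. The result shows that this place does not treat the two aromatic rings alike, even though each carries 1 hetero atom and 1 hydrogen-bond acceptor, so those matching counts do not keep the read-out near that of compound 1.

Going by these compounds, the step changes ring size and hetero atom together, from a five-membered ring with oxygen to a six-membered ring with nitrogen, so these compounds do not show which of the two goes with the higher number, and the full size of the step stays unknown past the limit. On these data alone, the standing of a pyridin-3-yl, a pyridin-4-yl or a thiophen-3-yl ring at the same place, on the same dichloroacetamide, remains open.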